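The source may report more compounds than this note shows. Statements on the series, on what has been measured and on what is new or still open speak of the compounds shown alone.

Of the compounds shown here, three built on a shared core have been measured in an assay on cell membranes for displacement of a labelled ligand from Substance-K receptor (Homo sapiens); on this read-out higher numbers stand for weaker inhibition and lower numbers for stronger inhibition. Compound 1 `CC(C)NC(=O)c1c(CN2CCN(C(C)C)CC2)c(-c2ccccc2)nc2ccccc12` gives 811 nM, compound 2 `CCC(CC)NC(=O)c1c(CN2CCN(C(C)C)CC2)c(-c2ccccc2)nc2ccccc12` gives 18.5 nM, and compound 3 `C[C@H](NC(=O)c1c(CN2CCC(N)CC2)c(-c2ccccc2)nc2ccccc12)C1CCCCC1` gives 33 nM. Compound 3 thus stands second of the three numbers: its gap to compound 2 lies within the scatter, while its gap to compound 1 lies well beyond it. Compound 4 `C[C@H](NC(=O)c1c(CN2CCC(N3CCCCC3)CC2)c(-c2ccccc2)nc2ccccc12)C1CCCCC1` differs from compound 3 by piperidin-1-yl in place of amino on a saturated ring carbon. Among the measured compounds shown here, the only measured step, a 44-fold lower number from compound 1 to compound 2 (1.64 log units; beyond the scatter), concerns the amide-type nitrogen and not this place, so no measured step bears on the change. The expected step is therefore no change at the digits printed from compound 3 to compound 4 (within the scatter), within the scatter. Compound 4 is estimated at 33 nM, with a range from 10 nM to 110 nM.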

Compound 4, inhibition constant: 0.6 nM
For compound 4 the middle estimate is 55-fold (1.74 log units) above the measured one; the whole stated range lies above it.
By their numbers in this assay, from the lowest: compound 4; then compounds 2 and 3 (each within the scatter of the next); then compound 1.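

At this position, on the saturated ring carbon three ring bonds from the ring nitrogen, this assay responds strongly to the group carried: piperidin-1-yl in place of amino gives a 55-fold lower number from compound 3 to compound 4 (1.74 log units; beyond the scatter). The free amino group, with its hydrogen-bond donor, is therefore not needed for a low number here, and the larger ring is well accepted. Nothing at hand explains why the number falls.

As far as these compounds go, it remains open whether the ring nitrogen of piperidin-1-yl matters, which a cyclohexyl group would test, or whether a dimethylamino group would give a similar step. From the compounds shown here alone, it is also open whether the same change would carry over to the compounds with a pentan-3-yl amide.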